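This account rests on a few compounds, and the source may have more. Where it says the series, first, only, none or still open, it means among the compounds named here.

Measured in an ADME assay on THP-1 cells (Homo sapiens) for cytotoxicity, read by flow cytometry and propidium iodide staining, with a stated time of 72 h; on this read-out higher numbers stand for weaker inhibition and lower numbers for stronger inhibition:
- compound 1 `Cc1nc(CS(=O)(=O)c2ccc(Cl)cc2)c([N+](=O)[O-])n1C`: 68000 nM
- compound 2 `Cc1ccc(S(=O)(=O)Cc2nc(C)n(CCO)c2[N+](=O)[O-])cc1`: 59000 nM

Compound 2, at 59000 nM, stands within the scatter of compound 1, at 68000 nM, so the two numbers are not separated. The next compound is compound 3 `Cc1nc(CS(=O)(=O)c2ccc(Cl)cc2)c([N+](=O)[O-])n1CCO`, which differs from compound 2 as follows: chloro in place of methyl on an aromatic carbon. This is chloro in place of methyl on an aromatic carbon. For the measured compounds named here, no measured step covers this change, and no step beyond the scatter is expected in this assay. The expected size of the change is a 1.0-fold higher number from compound 2 to compound 3 (0.01 log units; within the scatter). For compound 3 the estimated value is 60000 nM, with an expected range of 30000 nM to 110000 nM.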

Compound 3, half-maximal inhibitory concentration: 578000 nM
Beside the measured number, compound 3's estimate is 9.6-fold (0.98 log units) below it; measured number above the stated range.
By their numbers in this assay, from the lowest: compounds 2 and 1 (each within the scatter of the next); then compound 3.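

In this assay, 4-methylphenyl to 4-chlorophenyl gives a 9.8-fold higher number from compound 2 to compound 3 (0.99 log units; beyond the scatter), so this place on the aromatic ring is not silent when the hydroxymethyl-extended chain is present. With the chloro held fixed, hydroxymethyl in place of hydrogen on the saturated chain carbon bound to an aromatic nitrogen gives an 8.5-fold higher number from compound 1 to compound 3 (0.93 log units; beyond the scatter), so the chain also moves the number. Nothing at hand bears on the reason for either step.

As far as these compounds go, whether the chloro step persists with an amine or a carboxylic acid on the chain stays open. So does the outcome with methoxy or fluoro in the same ring place.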